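From Difluoromethoxy to Isobutyl on a Shared Core

The source may hold more compounds than are shown below. What is called first, only, known or untested is meant among the compounds shown, and "the series" means these compounds.

Of the compounds shown here, three sharing one core have been tested in a functional assay on M21 cells (Homo sapiens) for antiproliferative activity, read by sulforhodamine B assay, with a stated time of 48 h; a lower number here means a stronger inhibitor, a higher number a weaker inhibitor. Compound 1 (`CCCCCCCc1ccc(NS(=O)(=O)c2ccc(N3CCNC3=O)cc2)cc1`), carrying heptyl, reads > 1000 nM, which is a limit and not a number. Compound 2 (`CC(C)(C)c1ccc(NS(=O)(=O)c2ccc(N3CCNC3=O)cc2)cc1`), carrying tert-butyl, reads > 1000 nM, again a limit. Among the compounds with values here, compound 3 (`O=C1NCCN1c1ccc(S(=O)(=O)Nc2ccc(OC(F)F)cc2)cc1`), carrying difluoromethoxy, gives 410 nM, the only true number so far.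

Compound 4 (`CC(C)Cc1ccc(NS(=O)(=O)c2ccc(N3CCNC3=O)cc2)cc1`) has isobutyl in place of difluoromethoxy on an aromatic carbon. Within the data shown here, two measured steps bear on this change, since heptyl and tert-butyl, like isobutyl, are made of carbon alone. They are an at least 2.4-fold lower number from compound 1 to compound 3 (0.38 log units; beyond the scatter) and an at least 2.4-fold lower number from compound 2 to compound 3 (0.38 log units; beyond the scatter), both beyond the scatter. On these data alone, each has a limit at one end, so its full size remains unknown. Running these steps in reverse, compound 4 is expected to give a higher number, meaning weaker inhibition. The expected change is a 3.2-fold higher number from compound 3 to compound 4 (0.50 log units; beyond the scatter). For compound 4 the estimated value is 1300 nM, within an expected range of 450 nM to 4000 nM.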

Compound 4, half-maximal inhibitory concentration: > 1000 nM
Compound 4 ended at the assay's limit (the forecaster's own chance of this, stated with the estimate: 55%); the middle value is on the limit's open side.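

Putting isobutyl in place of difluoromethoxy gives an at least 2.4-fold higher number from compound 3 to compound 4 (0.38 log units; beyond the scatter). Both groups hold 4 heavy atoms, so at this place, para to a large group, the weaker reading comes with no change in that count, only with carbon in place of oxygen and fluorine. In this assay compound 4 gives > 1000 nM, a limit and not a number.

On these data alone, the steps among compound 1, compound 2 and compound 4 cannot be read, so the order of heptyl, tert-butyl and isobutyl stays hidden: the limit of > 1000 nM in this assay, at which 3 of the 4 values shown sit. Whether the oxygen or the fluorine matters more for the true number of compound 3 also stays open, and methoxy or trifluoromethoxy at this place would help to separate the two.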